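The compounds below may be only part of what the source reports. "The series", "measured", "known", "first", "only" and "open" are said of these compounds alone.

Measured in a functional assay on Caco-2 cells (Homo sapiens), read by MTT assay, with a stated time of 48 h (a higher number here means a weaker inhibitor, a lower number a stronger inhibitor), so far:
Compound 1 `CCn1c(C(=O)NCCCN(C)C)ccc1C(CC)(CC)c1ccc(OCC(=O)C(C)(C)C)c(C)c1` with 1400 nM
Compound 2 `CCn1c(C(=O)NCCN)ccc1C(CC)(CC)c1ccc(OCC(=O)C(C)(C)C)c(C)c1` with 1900 nM

Only these two compounds have numbers, and the step of a 1.4-fold higher number from compound 1 to compound 2 (0.13 log units; within the scatter) keeps them together. Compound 2 therefore stands level with compound 1, and the pair gives no ranking.

The next compound, compound 3 `CC[C@@H](C)[C@H](NC(=O)c1ccc(C(CC)(CC)c2ccc(OCC(=O)C(C)(C)C)c(C)c2)n1CC)C(=O)O` keeps the shared core but alters the group on the amide. The difference is 1-carboxy-2-methylbutyl in place of 2-aminoethyl on an amide-type nitrogen and in words it is 1-carboxy-2-methylbutyl in place of 2-aminoethyl on an amide-type nitrogen.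

For the measured compounds named here, the one measured step bears on this only loosely. It swapped one amino-bearing chain for another, and neither measured compound shows what happens when a carboxy-bearing chain enters. In this assay a step beyond the scatter is therefore not firmly expected, though the tentative lean is towards a higher number, meaning a weaker inhibitor. The expected step is a 1.6-fold higher number from compound 2 to compound 3 (0.20 log units; within the scatter) and this remains an uncertain estimate. For compound 3 the estimate is 3000 nM with an expected range from 900 nM to 12000 nM in this measurement.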

Compound 3, half-maximal inhibitory concentration: 4500 nM
Compound 3: the middle estimate sits 1.5-fold (0.18 log units) below what was measured, within the range that was stated.
By their numbers in this assay, from the lowest: compounds 1 and 2 (each within the scatter of the next); then compound 3.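

In this assay, for the compounds shown here, the amide-type nitrogen proves sensitive to the group it carries: 1-carboxy-2-methylbutyl in place of 2-aminoethyl gives the first step at this position that lies beyond the scatter (a 2.4-fold higher number from compound 2 to compound 3 (0.37 log units; beyond the scatter)), and the step from the 3-(dimethylamino)propyl chain is of the same modest order (a 3.2-fold higher number from compound 1 to compound 3 (0.51 log units; beyond the scatter)). The two amine-bearing chains stay together, so compound 3, with its carboxylic acid, is the only one of the three that stands apart, and it has the highest number, meaning the weakest inhibitor of the set. The change is still a composite one, as a carboxylic acid, a branched carbon chain and two defined stereocentres all enter in a single step, and no measurement is available to explain the shift.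

The compounds shown leave open whether the step follows the carboxylic acid or the branched carbon chain, which a methyl ester of compound 3 or an unbranched chain ending in a carboxylic acid would help to separate. On these data alone, it also remains open how the opposite configuration at the two stereocentres, or a plain alkyl chain with neither amine nor carboxylic acid, would read in this assay.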